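The source may report more compounds than this note shows. Statements on the series, on what has been measured and on what is new or still open speak of the compounds shown alone.

Compound 1 `O=C(COc1ccc(C(=O)/C=C/c2ccc(Br)cc2)cc1)N[C@H]1CCOC1=O`: > 64000 nM
Compound 2 `O=C1OCC[C@@H]1NC(=S)SCCOc1ccccc1[N+](=O)[O-]`: 24000 nM
Compound 3 `O=C(CNc1ccc(Br)cc1)N[C@H]1CCOC1=O`: > 64000 nM

All three were tested in a functional assay on PC-3 cells (Homo sapiens) for antiproliferative activity, read by MTT assay, with a stated time of 72 h; a lower number here means a stronger inhibitor, a higher number a weaker inhibitor. Compound 1 gives > 64000 nM, which is a limit of the assay and not a number. Compound 3 likewise gives > 64000 nM, again a limit. Among the measured compounds shown here, compound 2 gives 24000 nM, the only true number among the three. Compound 1 therefore stands at the limit of > 64000 nM in this assay, at which 2 of the 3 values shown sit. No ranking of compound 1 against compound 3 can be made, and the only thing known is that compound 2 sits at a measured number where compound 1 does not.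

Compound 4 `O=C(COc1ccc(C(=O)/C=C/c2ccc(Cl)cc2Cl)cc1)N[C@H]1CCOC1=O` has not yet been measured in this assay. It differs from compound 1 in one place: 2,4-dichlorophenyl in place of 4-bromophenyl on a double-bonded chain carbon bound to a double-bonded chain carbon. For the measured compounds named here, no step between measured compounds is known, and the change keeps the rest of the molecule the same. The step of an at least 1.0-fold lower number from compound 1 to compound 4 (0.02 log units; that floor lies within the scatter) is expected to be none beyond the scatter. Compound 4 is accordingly estimated at 60000 nM, with a range from 15000 nM to 200000 nM, and a good chance that only a limit is reported once more.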

Compound 4, half-maximal inhibitory concentration: 8040 nM
Compound 4: the middle estimate sits 7.5-fold (0.87 log units) above what was measured; measured number below the stated range.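

Placing 2,4-dichlorophenyl where 4-bromophenyl stood, on a double-bonded chain carbon bound to a double-bonded chain carbon, gives in this assay an at least 7.9-fold lower number from compound 1 to compound 4 (0.90 log units; beyond the scatter) and so shows that a change at this position alone can move the read-out. The earlier compounds shown here offered no pair differing in one place, so they could not show this. The true size of the step remains unknown, and it can be stated only as a floor because compound 1 carries a limit of the assay and not a number: the limit of > 64000 nM in this assay, at which 2 of the 4 values shown sit.

The data do not tell whether the added chlorine or the loss of bromine produces the change, and no measured property explains it. A 4-chlorophenyl group would separate those two changes, while a ring bearing a methoxy group or an amine at this position remains untested among the compounds shown.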